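Azetidinyl oxadiazole amides and ureas: step to compound 4

The source may report more compounds than this note shows. Statements on the series, on what has been measured and on what is new or still open speak of the compounds shown alone.

compound 1 `COC1CCN(C(=O)N2CC(c3nc(-c4cccc(Cl)c4)no3)C2)CC1` — > 10000 nM
compound 2 `Cc1cccc(-c2noc(C3CN(C(=O)c4ccccc4F)C3)n2)c1` — 1400 nM
compound 3 `O=C(c1ccc(F)cc1)N1CC(c2nc(-c3cccc(F)c3)no2)C1` — > 10000 nM

In an assay on HEK293 cells for negative allosteric modulation of metabotropic glutamate receptor 5 (Homo sapiens), read by FLIPR (a lower number here means a stronger inhibitor, a higher number a weaker inhibitor), compound 1 gives only an assay limit, > 10000 nM, not a number. Compound 3 likewise returns only the limit > 10000 nM. Compound 2 gives 1400 nM. Among the compounds with values here, compound 1 thus stands at the limit of > 10000 nM in this assay, at which 2 of the 3 values shown sit, and no measured step leads from it to any other compound in this assay. Compound 4 `CC1CCN(C(=O)N2CC(c3nc(-c4cccc(Cl)c4)no3)C2)C1` alters the carbonyl substituent: 3-methylpyrrolidin-1-yl in place of 4-methoxypiperidin-1-yl on a carbonyl carbon. Within the data shown here, no measured pair covers a change of this kind, so no step size can be read from the series; compound 4 is expected to stay weak, most likely again at the limit. The expected step of an at least 1.1-fold lower number from compound 1 to compound 4 (0.04 log units; that floor lies within the scatter) is estimated to lie within the scatter. Compound 4 is estimated at 9000 nM, between 3000 nM and 30000 nM.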

Compound 4, half-maximal inhibitory concentration: > 10000 nM
Compound 4 gave a limit, no number (the forecaster's own chance of this, stated with the estimate: 60%); middle value at least 1.1-fold (0.04 log units) away from the limit.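

Within the data shown here, compound 1 and compound 4 both return only an assay limit, so no step between them can be read: the limit of > 10000 nM in this assay, at which 3 of the 4 values shown sit.

Going by these compounds, whether 3-methylpyrrolidin-1-yl in place of 4-methoxypiperidin-1-yl on a carbonyl carbon shifts inhibition at all remains open.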